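A few compounds are considered here, and "the series" means these few. Any claim that something is new, unique, unknown or untested is made for them only; others in the source may bear on it.

Compound 1 `Oc1cccc(-c2cc(-c3ccc(Cl)cc3)nc(-c3cccs3)c2)c1` gives the highest number of the three compounds measured in a functional assay on T47D cells (Homo sapiens) for cytotoxicity, read by CCK-8 assay and cell counting, with a stated time of 2 days (on this read-out higher numbers stand for weaker inhibition and lower numbers for stronger inhibition), at 10500 nM. Compound 2 `Oc1ccc(-c2cc(-c3ccsc3)nc(-c3cccc(Cl)c3)c2)cc1` gives 7390 nM, and compound 3 `Oc1cccc(-c2cc(-c3cccc(Cl)c3)nc(-c3cccs3)c2)c1` gives 3410 nM. Among the compounds with values here, the one single-point step measured, a 3.1-fold lower number from compound 1 to compound 3 (0.49 log units; beyond the scatter), concerns the chlorophenyl group rather than the group altered here. Compound 4 `Oc1cccc(-c2cc(-c3ccncc3)nc(-c3ccc(Cl)cc3)c2)c1` differs from compound 1 in one place: pyridin-4-yl in place of thiophen-2-yl on an aromatic carbon. Within the data shown here, no measured step bears directly on this replacement, since compound 2 differs from compound 1 in more than one place. With nothing pointing clearly either way, the step of a 1.2-fold lower number from compound 1 to compound 4 (0.09 log units; within the scatter) is expected to stay within the usual scatter. Compound 4 is therefore estimated at about 8500 nM in this assay, with a range from 3000 nM to 25000 nM.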

Compound 4, half-maximal inhibitory concentration: 3330 nM
The estimate for compound 4 lay 2.6-fold (0.41 log units) above the measured number; the measured number falls inside the stated range.
By their numbers in this assay, from the lowest: compounds 4 and 3 (each within the scatter of the next); then compounds 2 and 1 (each within the scatter of the next).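

In this assay, the change of thiophen-2-yl to pyridin-4-yl next to the ring nitrogen gives a 3.2-fold lower number from compound 1 to compound 4 (0.50 log units; beyond the scatter), the first measured sign that the read-out responds to the group at this position. A six-membered aromatic ring is accepted there, and the lower number stands for stronger inhibition. Nothing available explains this step. The compounds shown leave open whether the ring nitrogen or the larger ring accounts for the step, which a plain phenyl group at this position would help separate. On these data alone, how an amine or a carboxylic acid on that ring would read also remains open.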